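Methyl Addition on Two Fused Five-Ring Cores: Opening Notes

The compounds below may be only part of what the source reports. "The series", "measured", "known", "first", "only" and "open" are said of these compounds alone.

Three compounds carry a number in a functional assay for inhibition, with Homo sapiens as the target (on this read-out lower numbers stand for stronger inhibition and higher numbers for weaker inhibition), so far, and every one of them is a limit. Compound 1 `CCOC(=O)Cn1ncc2cncn2c1=O` gives > 48000 nM in this assay, which is a limit and not a number. Compound 3 `Cc1ncn2c(S)nncc12` gives > 48000 nM in this assay, again a limit. Compound 2 `Cc1nc(C)n2c(S)nncc12` gives > 48000 nM in this assay, also a limit. The common thread is the limit of > 48000 nM in this assay, at which 3 of the 3 values shown sit.

Compound 2 arises from compound 3 by methyl in place of hydrogen on an aromatic carbon. The step that the two limits leave unreadable from compound 3 to compound 2 cannot be read, since both ends sit at the limit.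

Compound 4 `CCOC(=O)Cn1ncc2c(C)ncn2c1=O` is not yet measured. It arises from compound 1 by methyl in place of hydrogen on an aromatic carbon. Within the data shown here, this is the same kind of change as the one from compound 3 to compound 2, but not the same: in compound 4 the place is "next to the ring nitrogen; two ring bonds from the ring nitrogen", whereas in compound 2 it is "between two ring nitrogen atoms; two ring bonds from the ring atom that bears a methyl group". The difference between the core of compound 1 and the core of compound 3 is not broken down here.

For compound 4 the step that the limit leaves unreadable from compound 1 to compound 4 is expected to stay unreadable, resting only on compound 1 at > 48000 nM and on the measured pair, where the same kind of change left both partners at the limit. The estimate for compound 4 in this assay is therefore 70000 nM, with a range from 20000 nM to 250000 nM, and most likely another limit rather than a number.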

Compound 4, half-maximal inhibitory concentration: > 48000 nM
Compound 4: a limit, no number; the forecaster's own chance of this, stated with the estimate: 85%; the middle value lies beyond the limit too.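

In this assay compound 4 gives > 48000 nM as a limit and not a number. No step can be read from compound 1 to compound 4, because both stand at the same limit: the limit of > 48000 nM in this assay, at which 4 of the 4 values shown sit.

The compounds shown leave open whether methyl in place of hydrogen on an aromatic carbon changes inhibition on either core; none of the four carries a readable number.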